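The source may report more compounds than this note shows. Statements on the series, on what has been measured and on what is new or still open speak of the compounds shown alone.

Compound 1 `COc1ccc(-c2cc3ccccc3nc2C=O)cc1` carries the shared core with an aldehyde attached to it. In a functional assay on A549 cells (Homo sapiens) for antiproliferative activity, read by XTT assay, with a stated time of 72 h (a lower number here means a stronger inhibitor, a higher number a weaker inhibitor), compound 1 gives only a limit of the assay, > 10000 nM. Compound 2 `COc1ccc(-c2cc3ccccc3nc2/C=C/C(=O)c2ccc(N)cc2)cc1` stretches that aldehyde into an unsaturated ketone ending in a 4-aminophenyl group, and in this assay compound 2 gives 7530 nM. Compound 3 `COc1ccc(-c2cc3ccccc3nc2/C=C/C(=O)c2ccc([N+](=O)[O-])cc2)cc1` carries a nitro group where compound 2 carries an amino group; in this assay compound 3 gives 6310 nM. The step of a 1.2-fold lower number from compound 2 to compound 3 (0.08 log units; within the scatter) lies within the scatter, so the two numbers cannot be told apart. Compound 3 thus stands at the lower of the two measured numbers, with compound 2 so close that the difference means nothing.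

Compound 4 `COc1ccc(-c2cc3ccccc3nc2/C=C/C(=O)c2cccs2)cc1` has not yet been measured. It differs from compound 3 in one place: thiophen-2-yl in place of 4-nitrophenyl on a carbonyl carbon. Within the data shown here, the only measured step that touches this end of the molecule is a 1.2-fold lower number from compound 2 to compound 3 (0.08 log units; within the scatter), and exchanging one group for another there moved nothing beyond the scatter. Swapping the whole ring is a larger change that no measured pair covers. The expected step is therefore small: compound 4 is expected to show a 1.1-fold lower number from compound 3 to compound 4 (0.02 log units; within the scatter). Compound 4 is estimated at about 6000 nM, likely between 2500 nM and 15000 nM.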

Compound 4, half-maximal inhibitory concentration: 920 nM
Compound 4: middle estimate off by 6.5-fold (0.81 log units), on the high side; the whole stated range lies above it.
By their numbers in this assay, from the lowest: compound 4; then compounds 3 and 2 (each within the scatter of the next). At a limit, above all of these: compound 1.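

The group on the carbonyl carbon turns out to matter for antiproliferative activity, which compounds 2 and 3 could not show: exchanging amino for nitro on the phenyl ring left a 1.2-fold lower number from compound 2 to compound 3 (0.08 log units; within the scatter), so the ring's outer substituent made no measurable difference. Replacing the whole ring does make a difference in this assay, with thiophen-2-yl in place of 4-nitrophenyl giving a 6.9-fold lower number from compound 3 to compound 4 (0.84 log units; beyond the scatter) and thiophen-2-yl in place of 4-aminophenyl giving an 8.2-fold lower number from compound 2 to compound 4 (0.91 log units; beyond the scatter). The longer unsaturated ketone bearing thiophen-2-yl, set against the aldehyde, gives an at least 10-fold lower number from compound 1 to compound 4 (1.03 log units; beyond the scatter), a step that starts from a limit rather than a number: the limit of > 10000 nM in this assay, at which 1 of the 4 values shown sits.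

The compounds shown leave open whether the lower number goes with the sulfur atom, the five-membered ring or the loss of the substituted phenyl ring; an unsubstituted phenyl, a furan-2-yl and a thiophen-3-yl on the same carbonyl carbon would help separate these. Also open, going by these compounds, is what the double bond of the chain contributes, which a saturated chain carrying the same thiophen-2-yl ketone would test.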